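This account rests on a few compounds, and the source may have more. Where it says the series, first, only, none or still open, it means among the compounds named here.

In a functional assay on HOS-TE85 cells (Homo sapiens) for inhibition, read by CCK-8 assay, with a stated time of 72 h (on this read-out higher numbers stand for weaker inhibition and lower numbers for stronger inhibition), the compounds read as follows
Compound 1 (`O=C(NCCCCn1cccn1)c1cccc(C2SCC(=O)N2c2cc(Br)ccn2)c1`) gives 105 nM
Compound 2 (`Cc1ccnc(N2C(=O)CSC2c2cccc(C(=O)NCCCCn3cccn3)c2)c1`) gives 19.6 nM
Compound 3 (`O=C(NCCCCn1cccn1)c1cccc(C2SCC(=O)N2c2cc(Cl)ccn2)c1`) gives 36.4 nM

Compound 3 stands level, within the scatter, with its nearest neighbour (a 1.9-fold higher number from compound 2 to compound 3 (0.27 log units; within the scatter)) and clearly under the highest number of the three (a 2.9-fold lower number from compound 1 to compound 3 (0.46 log units; beyond the scatter)). Compound 4 (`O=C(NCCCCn1cccn1)c1cccc(C2SCC(=O)N2c2cccc(C3CC3)c2)c1`) carries 3-cyclopropylphenyl in place of 4-chloropyridin-2-yl on an amide-type nitrogen in a ring. The measured steps at this group only exchange one substituent on an aromatic carbon (a 5.4-fold lower number from compound 1 to compound 2 (0.73 log units; beyond the scatter) and a 2.9-fold lower number from compound 1 to compound 3 (0.46 log units; beyond the scatter)), and both are modest. Among the compounds with values here, no measured compound shows the whole aromatic group replaced, so these steps give only a rough guide to size and no direction. In this assay a change of about that modest size is the most that can reasonably be expected, and a shift beyond the scatter is not predicted either way. The estimated step is small (a 1.2-fold lower number from compound 3 to compound 4 (0.08 log units; within the scatter)). For compound 4 the expected value is 30 nM (estimated range 6 nM to 130 nM).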

Compound 4, half-maximal inhibitory concentration: 299 nM
Compound 4: middle estimate off by 10-fold (1.00 log units), on the low side, outside the stated range (above it).
By their numbers in this assay, from the lowest: compounds 2 and 3 (each within the scatter of the next); then compound 1; then compound 4.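

In this assay, exchanging the whole aromatic group on the amide-type nitrogen in the ring gives the first direction at this position, and every comparison with compound 4 moves upward (an 8.2-fold higher number from compound 3 to compound 4 (0.91 log units; beyond the scatter); a 15-fold higher number from compound 2 to compound 4 (1.18 log units; beyond the scatter); a 2.8-fold higher number from compound 1 to compound 4 (0.45 log units; beyond the scatter)). The earlier steps shown here changed only one substituent on a pyridin-2-yl group, whereas 3-cyclopropylphenyl leaves compound 4 with the weakest inhibition of the four, so this replacement costs more than any difference among the halogen and methyl compounds could indicate in direction. No available measurement accounts for this rise.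

The compounds shown leave open whether the rise follows from the change of pyridin-2-yl to phenyl or from the cyclopropyl group itself. An unsubstituted phenyl, or a pyridin-2-yl group carrying cyclopropyl, would separate these two changes.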